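Fluoro to methoxy in a weakly growth-inhibiting series

A few compounds are considered here, and "the series" means these few. Any claim that something is new, unique, unknown or untested is made for them only; others in the source may bear on it.

Of the compounds shown here, three have been measured in a functional assay on A2780 cells (Homo sapiens) for inhibition, read by sulforhodamine B assay; a lower number here means a stronger inhibitor of growth, a higher number a weaker inhibitor of growth. Compound 1 (`Fc1ccc(-c2ccc(-c3ccc(-c4nc5ccccc5[nH]4)cc3)cc2)cc1`) gives 48200 nM, compound 2 (`COc1ccc(-c2ccc(-c3ccc(-c4nc5ccccc5[nH]4)cc3)cc2)cc1OC`) gives 21600 nM, and compound 3 (`Oc1cccc2[nH]c(-c3ccc(-c4ccc(-c5ccc(F)cc5)cc4)cc3)nc12`) gives 41200 nM. Compound 3 therefore lies within the scatter of both other compounds.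

Compound 4 (`COc1ccc(-c2ccc(-c3ccc(-c4nc5c(O)cccc5[nH]4)cc3)cc2)cc1`) keeps the hydroxy group of compound 3 but carries methoxy in place of fluoro on an aromatic carbon, para to a large group, so that 4-fluorophenyl becomes 4-methoxyphenyl: methoxy in place of fluoro on an aromatic carbon.

Among the compounds with values here, two measured steps bear on this change. The nearest is a 2.2-fold lower number from compound 1 to compound 2 (0.35 log units; beyond the scatter), with 3,4-dimethoxyphenyl in place of 4-fluorophenyl. It is modest, and it is a larger structural change than the one at hand. Within the data shown here, the other is a 1.2-fold lower number from compound 1 to compound 3 (0.07 log units; within the scatter), which installs the hydroxy group and stays within the scatter, so nothing measured suggests that the hydroxy group alters the comparison, though no pair tests this directly.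

A small move towards a lower number is therefore expected, smaller than the dimethoxy step and probably within the scatter. The estimate amounts to an expected 1.5-fold lower number from compound 3 to compound 4 (0.17 log units; within the scatter). For compound 4 the expected value is 28000 nM, with an estimated range from 12000 nM to 55000 nM.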

Compound 4, concentration for 50% growth inhibition: 8640 nM
Beside the measured number, compound 4's estimate is 3.2-fold (0.51 log units) above it; the whole stated range lies above it.
By their numbers in this assay, from the lowest: compound 4; then compounds 2, 3 and 1 (each within the scatter of the next, the first and the last beyond it).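

The step of a 4.8-fold lower number from compound 3 to compound 4 (0.68 log units; beyond the scatter) in this assay shows that the group on the outer ring, para to a large group, can matter in this series, and that a single methoxy in place of fluoro is enough to move the number beyond the scatter. The earlier step at this ring, a 2.2-fold lower number from compound 1 to compound 2 (0.35 log units; beyond the scatter), was a larger structural change, replacing 4-fluorophenyl with 3,4-dimethoxyphenyl on a core without the hydroxy group, yet it was described as smaller in size. Within the data shown here, the hydroxy group alone gave only a 1.2-fold lower number from compound 1 to compound 3 (0.07 log units; within the scatter), so the new step is the first sign that this compound with the hydroxy group responds to a change at the far end of the molecule. Nothing available accounts for the size of this step.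

Whether the step depends on the hydroxy group stays open, as the compounds shown include no pair with 4-methoxyphenyl on both the hydroxy-bearing core and the core of compound 1. As far as these compounds go, it is also open whether an ethoxy group, a longer alkoxy chain or an amine at this place would follow methoxy or fluoro.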